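Removing the acetyl from the amide nitrogen of compound 2

This account rests on a few compounds, and the source may have more. Where it says the series, first, only, none or still open, it means among the compounds named here.

Of the compounds shown here, two sharing one core have been measured so far. Compound 1 `COc1cc2ccc(=O)oc2cc1OCCCCOc1no[n+]([O-])c1S(=O)(=O)c1ccccc1` carries a hydrogen on the aromatic carbon where compound 2 `COc1cc2cc(NC(C)=O)c(=O)oc2cc1OCCCCOc1no[n+]([O-])c1S(=O)(=O)c1ccccc1` carries an acetamido group. In a functional assay on MCF7 cells (Homo sapiens) for inhibition, read by MTT assay, with a stated time of 48 h, tested at 10 uM (on this read-out lower numbers stand for less inhibition and higher numbers for more inhibition at the one concentration tested (going by the name of the read-out)), compound 1 gives 84.4%, and in the same test compound 2 gives 80.4%. The change in the read-out a number 4 percentage points lower from compound 1 to compound 2 (within the scatter) shows that putting the acetamido group there left the number essentially where it was, and so the two measured compounds stand within the usual scatter of each other.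

Compound 3 `COc1cc2cc(N)c(=O)oc2cc1OCCCCOc1no[n+]([O-])c1S(=O)(=O)c1ccccc1` is the next candidate. It differs from compound 2 by hydrogen in place of acetyl on a nitrogen on an aromatic ring, so the acetamido group becomes a plain amino group. Going by the values given here, the only measured step that touches this part of the molecule is the one from compound 1 to compound 2, and that step stayed within the scatter. With no step beyond the scatter to build on, the expectation for compound 3 is a change a number 1.6 percentage points higher from compound 2 to compound 3 (within the scatter) that does not exceed the scatter. Compound 3 is therefore estimated at 82%, with a range from 68% to 92%.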

Compound 3, a percentage reported as inhibition, at one concentration (the size of the read-out at that concentration, not a potency): 89%
The estimate for compound 3 lay 7 percentage points below the measured number; the range from low to high includes it.
By their numbers in this assay, from the lowest: compounds 2, 1 and 3 (each within the scatter of the next).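

In this assay, replacing the acetyl on the nitrogen with hydrogen gives a number 8.6 percentage points higher from compound 2 to compound 3 (within the scatter), so removing the acetyl, like adding the acetamido group earlier, does not carry the number beyond the scatter. Compared directly with the hydrogen on the aromatic carbon, the amino group gives a number 4.6 percentage points higher from compound 1 to compound 3 (within the scatter), which means that hydrogen, amino and acetamido at this one place cannot be told apart on this test, and the three compounds offer no ranking among these groups. No measurement is available to explain these readings.

The compounds shown leave open whether a different group on that aromatic carbon, such as a carboxylic acid or a dimethylamino group, or a longer acyl chain on the nitrogen in place of acetyl, would move the number beyond the scatter. Since each compound was read at a single concentration, these numbers also leave open whether the three compounds would still be indistinguishable at lower concentrations, where a full concentration series could separate them.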